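Methyl for iodo on the aryl hydrazone of compound 1

The source may hold more compounds than are shown below. What is called first, only, known or untested is meant among the compounds shown, and "the series" means these compounds.

Compound 1, `CC1CC/C(=N\Nc2ccccc2I)c2ncc(C(=O)O)c(=O)n21`: > 1000 umol/kg
Compound 2, `C[C@@H]1CC/C(=N\Nc2ccc(O)cc2)c2ncc(C(=O)O)c(=O)n21`: > 100 umol/kg

Of the compounds shown here, two of this set have been tested in a functional assay on the whole organism for inhibition, with Rattus norvegicus as the target; a lower number here means that less compound is needed, a higher number that more compound is needed for the effect. In this assay compound 1 gives > 1000 umol/kg, which is a limit of the assay and not a number. In this assay compound 2 gives > 100 umol/kg, again a limit rather than a measured number. Compound 1 thus stands at the limit of > 1000 umol/kg in this assay, at which 1 of the 2 values shown sits, while the other value sits at the limit of > 100 umol/kg in this assay, at which 1 of the 2 values shown sits. Among the compounds with values here, since neither value is a number, no step between the two measured compounds can be sized, and no direction can be read from them.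

Compound 3, `Cc1ccccc1N/N=C1\CCC(C)n2c1ncc(C(=O)O)c2=O`, has not yet been measured in this assay. It differs from compound 1 in one place: methyl in place of iodo on an aromatic carbon. Within the data shown here, with no measured step to lean on, the expected step from compound 1 to compound 3 in this assay is a number no higher from compound 1 to compound 3 (the limit leaves the size open), that is, none beyond the scatter, because compound 1 itself only reaches > 1000 umol/kg. Compound 3 is therefore estimated at about 1000 umol/kg in this assay, with a range from 300 umol/kg to 3000 umol/kg, and most likely the assay will again report only a limit.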

Compound 3, dose for 50% inhibition: > 100 umol/kg
Compound 3 gave a limit, no number; the forecaster's own chance of this, stated with the estimate: 80%; the middle value does not contradict the limit.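

Within the data shown here, compound 1 and compound 3 both stand only at limits of the assay, not at numbers, and no step between them can be read in this assay. The compounds shown leave open whether methyl in place of iodo on the aromatic carbon changes the dose needed at all.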